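A Bigger Ring Amine on a Shared Two-Ring Core

The source may hold more compounds than are shown below. What is called first, only, known or untested is meant among the compounds shown, and "the series" means these compounds.

Of the compounds shown here, two have been tested so far in a functional assay on HCT-116 cells (Homo sapiens) for inhibition, read by luminescence and resazurin assay, with a stated time of 3 days; a higher number here means a weaker inhibitor, a lower number a stronger inhibitor. Compound 1 `CN1CCN(c2nc(NCc3ccc(NC(=O)c4ccc(F)cc4)cc3)c3ccccc3n2)CC1` gives 1800 nM. Compound 2 `CN(C)c1nc(NCc2ccc(NC(=O)c3ccncc3)cc2)c2ccccc2n1` gives 15000 nM, the higher of the two numbers, and its gap to compound 1 lies beyond the usual scatter of this kind of measurement. For the measured compounds named here, compound 1 and compound 2 differ from one another in more than one place, so no single step connects their values and nothing can be read from them about any one change on its own.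

Compound 3 `CN1CCN(c2nc(NCc3ccc(NC(=O)c4ccncc4)cc3)c3ccccc3n2)CC1` is not yet measured. It comes from compound 2 by one change: 4-methylpiperazin-1-yl in place of dimethylamino on an aromatic carbon. Compound 3 therefore carries the same ring amine as compound 1 while keeping the rest of compound 2. Going by the values given here, since compound 1, the only compound with this group, gives 1800 nM, the number for compound 3 is expected to fall below that of compound 2, by a step of a 3.3-fold lower number from compound 2 to compound 3 (0.52 log units; beyond the scatter) that goes beyond the scatter, though with wide uncertainty. The estimate for compound 3 in this assay is 4500 nM, within a range from 1500 nM to 13000 nM.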

Compound 3, half-maximal inhibitory concentration: > 20000 nM
Compound 3: only a limit was reported; the forecaster's own chance of this, stated with the estimate: 5%; at least 4.4-fold (0.64 log units) between middle value and limit.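

In this assay the result for compound 3 is a limit and not a number: the limit of > 20000 nM in this assay, at which 1 of the 3 values shown sits.

On the aromatic carbon between two ring nitrogen atoms, 4-methylpiperazin-1-yl in place of dimethylamino gives an at least 1.3-fold higher number from compound 2 to compound 3 (0.12 log units; that floor lies within the scatter), so this swap brings no drop in the number, and the true size of any rise stays hidden behind the limit. For the compounds shown here, with 4-methylpiperazin-1-yl held fixed, pyridin-4-yl in place of 4-fluorophenyl on the carbonyl carbon gives an at least 11-fold higher number from compound 1 to compound 3 (1.04 log units; beyond the scatter), the first single change in this set with a size beyond the scatter, which shows that the ring amine does not carry the activity of compound 1 on its own and that the group on the carbonyl has a large bearing on the result.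

The compounds shown leave open how dimethylamino would read when paired with 4-fluorophenyl on the carbonyl, which would show whether the ring amine matters at all once the pyridine is gone. They also leave open whether a plain phenyl on the carbonyl, or a morpholine ring at the aromatic carbon, would follow compound 1 or compound 3.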